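The source may report more compounds than this note shows. Statements on the series, on what has been measured and on what is new or still open speak of the compounds shown alone.

Compound 1 `O=C(NCc1ccc(S(=O)(=O)N2CCCCC2)cc1)c1cc2ccncc2[nH]1`: 1700 nM
Compound 2 `O=C(NCc1ccc(S(=O)(=O)N2CCCCC2)cc1)c1cnc2nccn2c1`: 130 nM
Compound 3 `O=C(NCc1ccc(S(=O)(=O)N2CCCCC2)cc1)c1ccc2nc[nH]c2c1`: > 10000 nM

Compound 3 stands at the limit of a functional assay on A2780 cells (Homo sapiens) for inhibition, read by sulforhodamine B assay, with a stated time of 72 h (on this read-out higher numbers stand for weaker inhibition and lower numbers for stronger inhibition), as the limit of > 10000 nM in this assay, at which 1 of the 3 values shown sits, records, so no number is known for it. Compound 4 `O=C(NCc1ccc(S(=O)(=O)N2CCCCC2)cc1)c1ccn2cncc2c1` differs from compound 3 by a group of 9 heavy atoms (7 carbon, 2 nitrogen; one five-membered aromatic ring with 2 hetero atoms, one six-membered aromatic ring with 1 hetero atom) in place of a group of 9 heavy atoms (7 carbon, 2 nitrogen; one five-membered aromatic ring with 2 hetero atoms, one six-membered aromatic ring of carbon only), on a carbonyl carbon. Among the compounds with values here, two measured steps bear on this: an at least 76-fold higher number from compound 2 to compound 3 (1.88 log units; beyond the scatter) and an at least 5.8-fold higher number from compound 1 to compound 3 (0.76 log units; beyond the scatter). Compound 2 and compound 1, both carrying a six-membered ring with a hetero atom, sit well below compound 3, and compound 4 also brings a hetero atom into the six-membered ring while losing the donor of compound 3. Compound 4 is therefore expected to give a lower number than compound 3, a step of an at least 6.6-fold lower number from compound 3 to compound 4 (0.82 log units; beyond the scatter). The estimate for compound 4 in this assay is 1500 nM, between 250 nM and 9000 nM.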

Compound 4, half-maximal inhibitory concentration: > 10000 nM
Compound 4 ended at the assay's limit; the forecaster's own chance of this, stated with the estimate: 25%; middle value at least 6.6-fold (0.82 log units) from the limit.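

A hetero atom in the six-membered ring does not by itself lower the number, even with the hydrogen-bond donor of compound 3 gone: the record shows an at least 76-fold higher number from compound 2 to compound 4 (1.88 log units; beyond the scatter) and an at least 5.8-fold higher number from compound 1 to compound 4 (0.76 log units; beyond the scatter). Compound 3 and compound 4 hold the same atoms joined differently, and neither arrangement gives a readable value in this assay. The result for compound 4 is a limit and not a number, so its step from compound 3 cannot be read: the limit of > 10000 nM in this assay, at which 2 of the 4 values shown sit.

On these data alone, it remains open how weak compound 3 and compound 4 really are. As far as these compounds go, it is also open whether an amine or a methoxy group on the ring system of compound 4 would bring a readable value.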